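The source may report more compounds than this note shows. Statements on the series, on what has been measured and on what is new or still open speak of the compounds shown alone.

In an assay on HEK293 cells for agonist activity at Toll-like receptor 8 (Homo sapiens) (on this read-out lower numbers stand for an effect already at smaller amounts and higher numbers for an effect only at larger amounts of compound), compound 1, `CCC[C@@H](CO)Nc1nc(N)nc(C)c1Cc1ccc(CNCCO)cc1OC`, gives 5370 nM, and compound 2, `CCC[C@@H](CCO)Nc1nc(N)nc(C)c1Cc1ccc(CNC)cc1OC`, gives 6460 nM; the two values sit within the scatter of each other. Compound 3, `CCC[C@@H](CCO)Nc1nc(N)nc(C)c1Cc1ccc(CNCC(N)=O)cc1OC`, reaches only the limit of this assay, > 10000 nM. On the numbers shown compound 3 therefore stands at the edge of what this assay resolves, at the limit of > 10000 nM in this assay, at which 1 of the 3 values shown sits, and its position relative to the other two is known only as a floor: an at least 1.5-fold higher number from compound 2 to compound 3 (0.18 log units; that floor lies within the scatter).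

Compound 4, `CCC[C@@H](CCO)Nc1nc(N)nc(C)c1Cc1ccc(CNCCO)cc1OC`, differs from compound 3 in one place: hydroxymethyl in place of carbamoyl on a saturated chain carbon bound to an amine nitrogen. Among the compounds with values here, the only measured step that bears on this change is the one in which carbamoyl entered, namely the step from compound 2 to compound 3, and its size is known only as a floor. Compound 1 carries the same 2-hydroxyethyl group on the amine nitrogen that enters in compound 4, and its value in this assay lies in the same region as that of compound 2. Compound 4 is therefore expected to return from the limit to a measurable number, an expected step of an at least 1.6-fold lower number from compound 3 to compound 4 (0.22 log units; that floor lies within the scatter). The estimate for compound 4 in this assay is 6000 nM, expected to fall between 3000 nM and 12000 nM.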

Compound 4, half-maximal effective concentration: > 10000 nM
Compound 4: no number, only a limit (the forecaster's own chance of this, stated with the estimate: 20%); middle value at least 1.6-fold (0.22 log units) away from the limit.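

In this assay compound 4 gives > 10000 nM, which is a limit and not a number. Compound 3 also sits at a limit, so the step between these two cannot be read, and neither carbamoyl nor hydroxymethyl at this place, on a saturated chain carbon bound to an amine nitrogen, gives a readable value: (the limit of > 10000 nM in this assay, at which 2 of the 4 values shown sit). Against the compounds that do have numbers, only floors can be stated (an at least 1.5-fold higher number from compound 2 to compound 4 (0.18 log units; that floor lies within the scatter); an at least 1.8-fold higher number from compound 1 to compound 4 (0.27 log units; that floor lies within the scatter)), so the 2-hydroxyethyl group on the amine does not by itself secure a reading, although compound 1, which carries it on a different hydroxy chain, gives 5370 nM.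

The compounds shown leave open how far past the limit compound 3 and compound 4 really lie, and so whether the hydroxy chain or the group on the amine makes any real difference to the value. They also leave open what an ethyl group or a carboxylic acid at this place would give.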